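The source may hold more compounds than are shown below. What is called first, only, known or untested is meant among the compounds shown, and "the series" means these compounds.

Compound 1 `O=C(Nc1cccc(-c2oc3cc(-c4ccc(F)cc4)ccc3c(=O)c2O)c1)c1ccccc1F`, compound 2 `Cc1ccccc1C(=O)Nc1cccc(-c2oc3cc(-c4ccc(F)cc4)ccc3c(=O)c2O)c1` and compound 3 `O=C(Nc1cccc(-c2oc3cc(-c4ccc(F)cc4)ccc3c(=O)c2O)c1)c1cccc(F)c1` share one core and differ only in the aromatic group attached to the amide carbonyl. In a functional assay on MCF7 cells (Homo sapiens) for antiproliferative activity, read by CCK-8 assay, with a stated time of 72 h (on this read-out lower numbers stand for stronger inhibition and higher numbers for weaker inhibition), compound 1 gives 7570 nM, compound 2 gives 2280 nM, and compound 3 gives 5770 nM, which places compound 3 second highest of the three, close to compound 1 and further from compound 2. Compound 4 `COc1cc(OC)cc(C(=O)Nc2cccc(-c3oc4cc(-c5ccc(F)cc5)ccc4c(=O)c3O)c2)c1` carries 3,5-dimethoxyphenyl in place of 3-fluorophenyl on a carbonyl carbon. The measured steps at this carbonyl carbon were a 1.3-fold lower number from compound 1 to compound 3 (0.12 log units; within the scatter) and a 2.5-fold higher number from compound 2 to compound 3 (0.40 log units; beyond the scatter), both at most modest, so a change of similar modest size is expected in this assay, with direction uncertain. Compound 4 is therefore estimated at 4000 nM, within 1500 nM to 12000 nM, a step of a 1.4-fold lower number from compound 3 to compound 4 (0.16 log units; within the scatter).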

Compound 4, half-maximal inhibitory concentration: 3470 nM
The estimate for compound 4 lay 1.2-fold (0.06 log units) above the measured number, within the range that was stated.
By their numbers in this assay, from the lowest: compounds 2, 4, 3 and 1 (each within the scatter of the next, the first and the last beyond it).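

At this carbonyl carbon in this assay, 3,5-dimethoxyphenyl brings the first hydrogen-bond acceptors on this aromatic ring, yet a 1.7-fold lower number from compound 3 to compound 4 (0.22 log units; within the scatter) and a 1.5-fold higher number from compound 2 to compound 4 (0.18 log units; within the scatter) both stay small, and only a 2.2-fold lower number from compound 1 to compound 4 (0.34 log units; beyond the scatter) passes the scatter, and then only modestly. Among these compounds, the number for compound 4 stays inside the range set by the earlier compounds, so this larger group with two methoxy substituents is accepted here without loss. As far as these compounds go, whether an amine or a carboxylic acid on this ring would shift the number further remains open. Nothing measured here explains these differences.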